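The source may hold more compounds than are shown below. What is called first, only, known or untested is meant among the compounds shown, and "the series" means these compounds.

Of the compounds shown here, two have so far been tested in a functional assay on NCI-H460 cells (Homo sapiens) for inhibition, read by sulforhodamine B assay, with a stated time of 48 h, tested at 10 uM; on this read-out lower numbers stand for less inhibition and higher numbers for more inhibition at the one concentration tested (going by the name of the read-out). Compound 1 `O=Cc1ccc(-c2cn3ccnc3c(-c3ccc4ncn(C5CCCCC5)c4c3)n2)cc1` gives 37.8% in this assay. Compound 2 `Cc1cccc(-c2cn3ccnc3c(-c3ccc4ncn(Cc5ccccc5)c4c3)n2)c1` gives 10.1% in this assay, the lowest of the two numbers; compound 1 stands higher by an amount that lies beyond the usual scatter. Among the compounds with values here, these two compounds differ in two places at once, so their gap cannot be assigned to either change on its own, and no step between measured compounds that differ in one place is available.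

Compound 3 `O=Cc1ccc(-c2cn3ccnc3c(-c3ccc4ncn(Cc5ccccc5)c4c3)n2)cc1` is the next member to be measured. Relative to compound 2 the difference is 4-formylphenyl in place of 3-methylphenyl on an aromatic carbon. Compound 3 thus carries the same 4-formylphenyl group as compound 1 on the rest of compound 2. Compound 1 gives 37.8% with that 4-formylphenyl group in place. A rise of moderate size is therefore expected a number 14.9 percentage points higher from compound 2 to compound 3 (beyond the scatter), though a result within the scatter of compound 2 cannot be ruled out. Compound 3 is estimated at 25% in this assay, within a range from 5% to 50%.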

Compound 3, a percentage reported as inhibition, at one concentration (the size of the read-out at that concentration, not a potency): 37.8%
The estimate for compound 3 lay 12.8 percentage points below the measured number; low and high end bracket the measured number.
By their numbers in this assay, from the lowest: compound 2; then compounds 1 and 3 (each within the scatter of the next).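

The substituent on the aromatic carbon now has a reading in one place: in this assay, 4-formylphenyl in place of 3-methylphenyl gives a number 27.7 percentage points higher from compound 2 to compound 3 (beyond the scatter). The substituent on the aromatic nitrogen, which could not be separated out before, also has its first reading: with 4-formylphenyl held fixed, benzyl in place of cyclohexyl gives no change at the digits printed from compound 1 to compound 3 (within the scatter), so these two groups are not told apart by this assay on this background. No measurement at hand explains either result.

From the compounds shown here alone, the step on the aromatic carbon swaps two things at once, the formyl group for a methyl group and its place on the phenyl ring, so the share of each in that step remains open, as does the outcome with a carboxylic acid or an amine in place of the formyl group. Going by these compounds, it is also open whether benzyl and cyclohexyl stay level alongside 3-methylphenyl, and how a longer chain or a smaller alkyl group on the aromatic nitrogen would read.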